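Dropping a hydroxy from the five-membered ring of compound 3

A few compounds are considered here, and "the series" means these few. Any claim that something is new, unique, unknown or untested is made for them only; others in the source may bear on it.

Of the compounds shown here, three have been measured in an assay on cells for inhibition of sodium/hydrogen exchanger (Oryctolagus cuniculus); a lower number here means a stronger inhibitor, a higher number a weaker inhibitor. Compound 1 `Cc1cc2c(cc1C(=O)N=C(N)N)S(=O)(=O)CCCC2` gives 19 nM, and compound 2 `COC1c2cc(C)c(C(=O)N=C(N)N)cc2S(=O)(=O)C1(C)C` gives 27 nM. Compound 3 `N=C(N)NC(=O)c1ccc2c(c1)S(=O)(=O)CC2O` stands apart: in this assay compound 3 gives 1500 nM, the highest of the three numbers, and its distance from both compound 2 and compound 1 lies well beyond the scatter of repeated measurements.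

The unmeasured compound 4 `N=C(N)NC(=O)c1ccc2c(c1)S(=O)(=O)CC2` differs from compound 3 in a single place: hydrogen in place of hydroxy on a saturated ring carbon. What remains is the same fused core of compound 3 with the amide-linked guanidine unchanged.

Among the compounds with values here, no measured pair shows this exact change, so no step of known size can be taken from the data. Compound 2 carries a methoxy on a saturated ring carbon and is potent, but its ring and its methyl groups differ too much from compound 3 for a direct reading. The estimate therefore leans on compound 3 itself and allows a wide margin. The step from compound 3 to compound 4 is expected to be modest, a 1.9-fold lower number from compound 3 to compound 4 (0.27 log units; within the scatter), with no confident direction. Compound 4 is estimated to give 800 nM in this assay, within a range from 200 nM to 3000 nM.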

Compound 4, half-maximal inhibitory concentration: 790 nM
For compound 4 the middle estimate is 1.0-fold (0.01 log units) above the measured one; the measured number falls inside the stated range.
By their numbers in this assay, from the lowest: compounds 1 and 2 (each within the scatter of the next); then compounds 4 and 3 (each within the scatter of the next).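

Hydrogen in place of hydroxy on this saturated ring carbon, two ring bonds from the ring sulfur, gives the first direct reading of a change at this position in this assay: a 1.9-fold lower number from compound 3 to compound 4 (0.28 log units; within the scatter). The hydroxy therefore shows no effect here that can be told from the usual variation between repeated measurements, and the pair gives no sign that it either helps or harms. On this pair alone, the hydroxy cannot be held responsible for the number of compound 3, 1500 nM, and no measurement beyond these potency numbers bears on the result.

The compounds shown leave open whether an amine or a carboxylic acid on this same ring carbon would shift the number beyond the scatter, as the only substituents compared here are hydroxy and hydrogen. Within the data shown here, they also leave open whether the same change would read alike on the cores of compound 1 and compound 2, as no pair on either core shows it.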